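Methyl to furan-2-yl on a carbonyl carbon

The source may hold more compounds than are shown below. What is called first, only, known or untested is meant among the compounds shown, and "the series" means these compounds.

In an ADME assay on Vero cells (Chlorocebus sabaeus) for cytotoxicity, read by MTT assay, with a stated time of 48 h (a higher number here means a weaker inhibitor, a lower number a stronger inhibitor), compound 1 `O=C(NC1CCC(CN2CCN(c3cc(=O)c4cc(C(F)(F)F)cc([N+](=O)[O-])c4s3)CC2)CC1)c1ccccc1` gives 44.3 ug/mL as a measured number. Compound 2 `Cc1ccc(C(=O)OC2CCC(CN3CCN(c4cc(=O)c5cc(C(F)(F)F)cc([N+](=O)[O-])c5s4)CC3)CC2)cc1` gives > 64 ug/mL, which is a limit and not a number. Compound 3 `CC(=O)OC1CCC(CN2CCN(c3cc(=O)c4cc(C(F)(F)F)cc([N+](=O)[O-])c4s3)CC2)CC1` gives > 64 ug/mL, again only a limit.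

Compound 4 `O=C(OC1CCC(CN2CCN(c3cc(=O)c4cc(C(F)(F)F)cc([N+](=O)[O-])c4s3)CC2)CC1)c1ccco1` differs from compound 3 in one place: furan-2-yl in place of methyl on a carbonyl carbon. The closest measured change, methyl in place of 4-methylphenyl on a carbonyl carbon, is a step that the two limits leave unreadable from compound 2 to compound 3, so it offers no size to carry over. The two changes away from compound 1 are an at least 1.4-fold higher number from compound 1 to compound 2 (0.15 log units; that floor lies within the scatter) and an at least 1.4-fold higher number from compound 1 to compound 3 (0.15 log units; that floor lies within the scatter), and neither gives a firm size.

Compound 2 holds an aromatic ring on that carbonyl carbon and sits at the limit of > 64 ug/mL in this assay, at which 2 of the 3 values shown sit, as does compound 3 with its methyl. No step beyond the scatter is therefore expected in this assay, and the estimated change is a step that the limit leaves unreadable from compound 3 to compound 4. For compound 4 the expected value is about 70 ug/mL, with an estimated range from 35 ug/mL to 128 ug/mL.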

Compound 4, half-maximal inhibitory concentration: > 64 ug/mL
Compound 4 gave a limit, no number; the forecaster's own chance of this, stated with the estimate: 70%; the middle value does not contradict the limit.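

In this assay, compound 4 sits at the same limit as compound 2 and compound 3, so furan-2-yl, 4-methylphenyl and methyl on that carbonyl carbon now all share it: the limit of > 64 ug/mL in this assay, at which 3 of the 4 values shown sit.
Both ends of each step among these three compounds are limits, so those steps cannot be read and the three groups cannot be ranked. Set against the benzamido group, the only group here with a measured number, ((furan-2-yl)carbonyl)oxy gives an at least 1.4-fold higher number from compound 1 to compound 4 (0.15 log units; that floor lies within the scatter).

On these data alone, it remains open whether another group on this carbonyl carbon, such as an aminomethyl group or a longer alkyl chain, would give a measured number in this assay. As far as these compounds go, it is also open how a furan-2-yl amide would read, which would show the effect of the amide link with the furan-2-yl group kept in place.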